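The compounds below may be only part of what the source reports. "The series", "measured", "known", "first", "only" and "open" are said of these compounds alone.

Measured compounds:
- compound 1 `O=C(Nc1ccccc1Cl)N1CCC(c2nc(-c3ccc4ccccc4n3)no2)CC1` — 510 nM
- compound 2 `O=C(CC1CCCCCC1)N1CCC(c2nc(-c3ccc4ccccc4n3)no2)CC1` — 840 nM
- compound 3 `Cn1c(-c2noc(C3CCN(C(=O)NC4CCCCC4)CC3)n2)nc2ccccc21` — 89 nM

In a functional assay on Shh Light II cells (Mus musculus) for inhibition, read by a luciferase reporter (a higher number here means a weaker inhibitor, a lower number a stronger inhibitor), compound 1 gives 510 nM, the second highest of the three numbers. Its nearest neighbour is compound 2, and the step from compound 1 to compound 2 is a 1.6-fold higher number from compound 1 to compound 2 (0.22 log units; within the scatter), a change of cycloheptylmethyl in place of (2-chlorophenyl)amino on a carbonyl carbon. For the measured compounds named here, compound 3 carries a different core and a cyclohexyl urea; no single-point step links it to compound 1, so its lower number can only be noted, not assigned to either difference.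

Compound 4 `CC(=O)N1CCC(NC(=O)N2CCC(c3nc(-c4ccc5ccccc5n4)no3)CC2)CC1` is the next compound, not yet measured in this assay. The change from compound 1 is 1-acetylpiperidin-4-yl in place of 2-chlorophenyl on an amide-type nitrogen. Going by the values given here, no measured step covers this exact exchange; the only step that bears on it, the one to compound 2, shows that a large change at the carbonyl end left the number within the scatter. On that basis the step expected in this assay from compound 1 to compound 4 is a 1.2-fold higher number from compound 1 to compound 4 (0.07 log units; within the scatter), with no confident direction. Compound 4 is therefore estimated at 600 nM, in a range from 200 nM to 2000 nM.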

Compound 4, half-maximal inhibitory concentration: 500 nM
Beside the measured number, compound 4's estimate is 1.2-fold (0.08 log units) above it; the range from low to high includes it.
By their numbers in this assay, from the lowest: compound 3; then compounds 4, 1 and 2 (each within the scatter of the next).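

In this assay, the amide-type nitrogen accepts either the aromatic 2-chlorophenyl or the non-aromatic 1-acetylpiperidin-4-yl, with a 1.0-fold lower number from compound 1 to compound 4 (0.01 log units; within the scatter) as the result, so this exchange of ring type leaves the number within the scatter. The comparison at the carbonyl carbon gives a 1.7-fold lower number from compound 2 to compound 4 (0.23 log units; within the scatter), which means that three quite different groups on the shared core, including one with a hydrogen-bond acceptor, now cannot be told apart in this assay. No measurement at hand accounts for this flat response.

On these data alone, it remains open whether a free piperidine amine or a carboxylic acid in place of the acetyl group would move the number beyond the scatter. As far as these compounds go, it is also open whether cyclohexylamino on the core of compound 1 would approach compound 3 at 89 nM and so separate the effect of the urea group from that of the core.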